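Changing the aromatic group on compound 3

This account rests on a few compounds, and the source may have more. Where it says the series, first, only, none or still open, it means among the compounds named here.

Compound 1 `CC1=CC[C@@H]([C@@](C)(O)CCCC(C)(C)NC(=S)NN)CC1` gives 380 nM in a functional assay on K562 cells (Homo sapiens) for cytotoxicity, read by sulforhodamine B assay (on this read-out higher numbers stand for weaker inhibition of growth and lower numbers for stronger inhibition of growth), and stands apart from its two relatives that carry an aromatic group. Compound 2 `COc1ccc(/C=N\NC(=S)NC(C)(C)CCC[C@](C)(O)[C@@H]2CC=C(C)CC2)cc1` gives 34900 nM and compound 3 `CC1=CC[C@@H]([C@@](C)(O)CCCC(C)(C)NC(=S)N/N=C\c2ccc(O)cc2)CC1` gives 31100 nM on the same read-out. Compound 3 therefore lies far from one neighbour and level with the other. Those two gaps are an 82-fold higher number from compound 1 to compound 3 (1.91 log units; beyond the scatter) and a 1.1-fold lower number from compound 2 to compound 3 (0.05 log units; within the scatter) as measured.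

Compound 4 `CC1=CC[C@@H]([C@@](C)(O)CCCC(C)(C)NC(=S)N/N=C\c2cccc([N+](=O)[O-])c2)CC1` differs from compound 3 by one change, 3-nitrophenyl in place of 4-hydroxyphenyl on a carbon with a double bond to nitrogen. The large step of a 92-fold higher number from compound 1 to compound 2 (1.96 log units; beyond the scatter) came with adding an aromatic group, and compound 4 keeps such a group. For the measured compounds named here, the only measured change on the aromatic ring itself, a 1.1-fold lower number from compound 2 to compound 3 (0.05 log units; within the scatter) once more, is small. Going by the values given here, no measured compound carries 3-nitrophenyl, so that small step is a thin guide and the range must stay wide. No step beyond the scatter is therefore expected in this assay for this swap. The expected step is a 1.0-fold lower number from compound 3 to compound 4 (0.02 log units; within the scatter) on this estimate. Compound 4 is estimated at 30000 nM with a likely range from 12000 nM to 75000 nM on this read-out.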

Compound 4, concentration for total growth inhibition: 560 nM
Compound 4: middle estimate off by 54-fold (1.73 log units), on the high side; measured number outside the range, below it.
By their numbers in this assay, from the lowest: compounds 1 and 4 (each within the scatter of the next); then compounds 3 and 2 (each within the scatter of the next).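

In this assay, replacing the ring group on the carbon with a double bond to nitrogen gives a 56-fold lower number from compound 3 to compound 4 (1.74 log units; beyond the scatter) and, starting from the methoxy relative, a 62-fold lower number from compound 2 to compound 4 (1.79 log units; beyond the scatter). This position is therefore far from flat: the earlier swap of hydroxyl for methoxy only showed that one exchange leaves the number unchanged, and a different group on the ring can shift it strongly. An aromatic ring alone also does not go with the high numbers, since compound 4 keeps one and yet lies within the scatter of compound 1, which has none. Nothing measured here gives a reason for a shift of this size.

The swap changes both the group and its place on the ring, so the compounds shown cannot say whether the low number belongs to the nitro group itself or to where it sits. A plain phenyl ring, or a 3-substituted ring carrying an amine or a carboxylic acid in place of the nitro group, would help separate these two readings.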